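The source may hold more compounds than are shown below. What is called first, only, known or untested is meant among the compounds shown, and "the series" means these compounds.

Series notes. In a functional assay on HBL-100 cells (Homo sapiens) for inhibition, read by sulforhodamine B assay, with a stated time of 48 h (a lower number here means a stronger inhibitor of growth, a higher number a weaker inhibitor of growth), compound 1 `CC(=O)OC/C(=C\c1ccc(F)cc1)C(=O)c1ccccc1` gives 17000 nM. In this assay, for the measured compounds named here, compound 2 `CC(=O)OC/C(=C\c1ccc([N+](=O)[O-])cc1)C(=O)c1ccccc1` gives 10000 nM, the low end of the two numbers recorded; the single step, a 1.7-fold lower number from compound 1 to compound 2 (0.23 log units; within the scatter), is within the scatter, so compound 1 and compound 2 are not separated by these data. Compound 3 `CC(=O)OC/C(=C/c1ccc([N+](=O)[O-])cc1)C(=O)c1ccccc1` is the next member: the two compounds have the same atoms and bonds and differ only in configuration as drawn: 1 of 1 stereo elements differ; a double bond is drawn E in compound 2 and Z in compound 3. Going by the values given here, no measured step concerns the geometry of the double bond; the only step in hand changes the substituent on the aromatic ring and does not bear on this change. With nothing comparable measured, no shift beyond the scatter is expected in this assay for compound 3 , and the range is kept wide. Compound 3 is estimated at 12000 nM, between 4000 nM and 40000 nM. For compound 3 this estimate means an expected step of a 1.2-fold higher number from compound 2 to compound 3 (0.08 log units; within the scatter).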

Compound 3, concentration for 50% growth inhibition: 41000 nM
Compound 3: the middle estimate sits 3.4-fold (0.53 log units) below what was measured; measured number above the stated range.
By their numbers in this assay, from the lowest: compounds 2 and 1 (each within the scatter of the next); then compound 3.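

In this assay the geometry of the double bond registers clearly, with a step of a 4.1-fold higher number from compound 2 to compound 3 (0.61 log units; beyond the scatter). For the compounds shown here, the only earlier step, which changes the substituent on the aromatic ring, stayed within the scatter, so this is the first change that separates two compounds. The shift can be assigned to the configuration alone, because nothing else separates the pair: the fact that compounds 2 and 3 differ only in the configuration as drawn

From the compounds shown here alone, whether the same change in geometry gives a step of similar size with fluoro in place of nitro stays open, since the fluoro compound appears here only as the E form. Also open, going by these compounds, is how either geometry behaves when the acetate ester gives way to another group, such as a free alcohol or an amine.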